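This account rests on a few compounds, and the source may have more. Where it says the series, first, only, none or still open, it means among the compounds named here.

Compound 1, `O=S(=O)(Nc1ccc2oc(-c3ccccc3)nc2c1)c1cccs1`, in an assay on isolated protein for inhibition of malate dehydrogenase, mitochondrial (Sus scrofa), with stated times of 45 min and 30 min (a lower number here means a stronger inhibitor, a higher number a weaker inhibitor), gives > 63000 nM, which is a limit of the assay and not a number.
Compound 2, `O=S(=O)(Nc1ccc2oc(-c3ccccc3)nc2c1)c1ccc(O)cc1`, in this assay gives > 63000 nM, again a limit of the assay rather than a number.

Among the measured compounds shown here, compound 2 therefore cannot be placed on a scale at all: its own value is a limit, and the one further value shown is the same limit, as the limit of > 63000 nM in this assay, at which 2 of the 2 values shown sit, records. For the measured compounds named here, the only step between measured compounds, a step that the two limits leave unreadable from compound 1 to compound 2, is consequently of unreadable size, and it says nothing about direction either. The unmeasured compound 3, `COc1cccc(S(=O)(=O)Nc2ccc3oc(-c4ccccc4)nc3c2)c1`, differs from compound 2 by 3-methoxyphenyl in place of 4-hydroxyphenyl on a sulfonyl sulfur. Going by the values given here, no measured step bears on this change in a readable way: the single step available has no size, so neither a gain nor a loss can be drawn from it. With both measured values sitting at the limit, the expectation for compound 3 in this assay is that it too will most likely be reported only as a limit, with no step beyond the scatter, a step that the limit leaves unreadable from compound 2 to compound 3. Compound 3 is accordingly estimated at 80000 nM, with a range from 30000 nM to 300000 nM.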

Compound 3, half-maximal inhibitory concentration: > 63000 nM
Compound 3: only a limit was reported; the forecaster's own chance of this, stated with the estimate: 85%; the middle value is on the limit's open side.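

In this assay compound 3 gives > 63000 nM, a limit of the assay and not a number. Its steps from compound 1 and compound 2 therefore cannot be read. All three compounds share one reading: the limit of > 63000 nM in this assay, at which 3 of the 3 values shown sit.

The compounds shown leave open whether thiophen-2-yl, 4-hydroxyphenyl and 3-methoxyphenyl on the sulfonyl sulfur differ at all, and in which direction.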